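Cytotoxicity of the series: methoxy replacing fluoro

A few compounds are considered here, and "the series" means these few. Any claim that something is new, unique, unknown or untested is made for them only; others in the source may bear on it.

Working notes on the series. Compound 1 `COc1ccc(-c2ccc(C)n2-c2ccc(-c3nc4ccc(F)cc4s3)cc2)cc1` is tested in an ADME assay on MCF-10A cells (Homo sapiens) for cytotoxicity, read by MTT assay, with a stated time of 72 h (on this read-out lower numbers stand for stronger inhibition and higher numbers for weaker inhibition), where compound 1 gives 37800 nM. Going by the values given here, compound 1 stands at the lowest of the two numbers so far, with compound 2 `Cc1ccc(-c2ccc([N+](=O)[O-])cc2)n1-c1ccc(-c2nc3ccc(F)cc3s2)cc1` nearest: in this assay compound 2 gives 39000 nM, and a 1.0-fold higher number from compound 1 to compound 2 (0.01 log units; within the scatter).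

Compound 3 `COc1ccc(-c2ccc(C)n2-c2ccc(-c3nc4ccc(OC)cc4s3)cc2)cc1` differs from compound 1 by methoxy in place of fluoro on an aromatic carbon. Among the compounds with values here, no measured step changes this position; the one step on record, from compound 1 to compound 2, concerns a different part of the core and stays within the scatter, so it gives no direct guidance on the present change. In the absence of a bearing step, no shift beyond the scatter is expected in this assay, and the step from compound 1 to compound 3 is estimated as a 1.1-fold higher number from compound 1 to compound 3 (0.02 log units; within the scatter). For compound 3 the expected value in this assay is therefore 40000 nM, with an estimated range from 18000 nM to 90000 nM.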

Compound 3, half-maximal inhibitory concentration: 30600 nM
For compound 3 the middle estimate is 1.3-fold (0.12 log units) above the measured one; the measured number falls inside the stated range.
By their numbers in this assay, from the lowest: compounds 3, 1 and 2 (each within the scatter of the next).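

In this assay, going by these compounds alone, the exchange at this position gives a first reading of its own (a 1.2-fold lower number from compound 1 to compound 3 (0.09 log units; within the scatter)), whereas the earlier step concerned a different part of the core. Methoxy, with 2 heavy atoms and 1 hydrogen-bond acceptor, stands here in place of fluoro, with 1 heavy atom and 0 hydrogen-bond acceptors, and the read-out shows no shift beyond the scatter. No measurement at hand accounts for this result.

As far as these compounds go, whether an amine, a carboxylic acid or a longer chain on this aromatic carbon would move the number in this assay beyond the scatter remains open. Also open, from the compounds shown here alone, is whether methoxy in place of fluoro would behave the same way in the core of compound 2, which carries nitro.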